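A few compounds are considered here, and "the series" means these few. Any claim that something is new, unique, unknown or untested is made for them only; others in the source may bear on it.

Working notes on the series. In a functional assay on CHO cells for agonist activity at metabotropic glutamate receptor 2 (Homo sapiens), read by scintillation counting and GTPgammaS binding, with a stated time of 30 min (on this read-out lower numbers stand for an effect already at smaller amounts and higher numbers for an effect only at larger amounts of compound), compound 2 `COc1c(F)cccc1C1CCN(c2ccn3c(CC4CC4)nnc3c2Cl)CC1` gives 37 nM, the higher of the two numbers recorded so far. Its nearest neighbour, compound 1 `COc1cccc(F)c1C1CCN(c2ccn3c(CC4CC4)nnc3c2Cl)CC1`, gives 6 nM in this assay. Among the compounds with values here, the one measured step, a 6.2-fold higher number from compound 1 to compound 2 (0.79 log units; beyond the scatter), arises from the 3-fluoro-2-methoxyphenyl in place of 2-fluoro-6-methoxyphenyl on a saturated ring carbon, a position that is left untouched in the next step.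

Compound 3 `COc1c(F)cccc1C1CCN(c2ccn3c(CC4CC4)nnc3c2C(F)(F)F)CC1` differs from compound 2 by trifluoromethyl in place of chloro on an aromatic carbon. Within the data shown here, no measured pair changes this aromatic carbon, so there is no step that bears on the size or direction of the exchange. The expectation therefore rests on the starting point alone, and the step is expected to stay near the scatter: from compound 2 to compound 3 a change of a 1.1-fold higher number from compound 2 to compound 3 (0.03 log units; within the scatter) in this assay is estimated, with no firm direction. Compound 3 is accordingly expected to give about 40 nM in this assay, with a range from 10 nM to 160 nM.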

Compound 3, half-maximal effective concentration: 11 nM
For compound 3 the middle estimate is 3.6-fold (0.56 log units) above the measured one, within the range that was stated.
By their numbers in this assay, from the lowest: compounds 1 and 3 (each within the scatter of the next); then compound 2.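

In this assay, within the data shown here, trifluoromethyl in place of chloro on this aromatic carbon gives the first measured step at this position, a 3.4-fold lower number from compound 2 to compound 3 (0.53 log units; beyond the scatter), which shows that the number responds to the group placed here, with the 3-fluoro-2-methoxyphenyl group held fixed. The entering group has 4 heavy atoms against 1 for the leaving one, and this exchange lowers the number rather than raising it, so the larger of these two groups is accepted at this carbon, ortho to a fused ring and ortho to a large group. Nothing in the data gives a reason for the size or direction of this step.

The compounds shown do not tell whether the same exchange would carry over to the 2-fluoro-6-methoxyphenyl group of compound 1, since this position has been compared only with the 3-fluoro-2-methoxyphenyl group in place. They also leave open how other groups on this aromatic carbon, such as a nitrile, a methyl or a methoxy, would compare with chloro and trifluoromethyl.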